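A methyl group added at the assay limit

The compounds below may be only part of what the source reports. "The series", "measured", "known", "first", "only" and "open" are said of these compounds alone.

In an ADME assay on THP-1 cells (Homo sapiens) for cytotoxicity (a higher number here means that more compound is tolerated, a lower number that less compound is tolerated), three compounds have been measured so far:

Compound 1 `c1ccc(-c2nc3ccccn3c2NC2CCNC2)nc1` gives > 50000 nM as a limit
Compound 2 `c1ccc(CNc2c(-c3ccccn3)nc3ccccn23)cc1` gives > 50000 nM as a limit
Compound 3 `Fc1cccc(Nc2c(-c3ccccn3)nc3ccccn23)c1` gives > 50000 nM as a limit

Among the compounds with values here, none of these is an exact number, and the whole evidence so far is the limit of > 50000 nM in this assay, at which 3 of the 3 values shown sit, with no measured compound yet giving a readable value. Compound 2 therefore has only a limit and cannot be ranked against the other two.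

Compound 4 `Cc1ccc2nc(-c3ccccn3)c(NCc3ccccc3)n2c1` differs from compound 2 at one place, with methyl in place of hydrogen on an aromatic carbon, as counted here: methyl in place of hydrogen on an aromatic carbon and the rest of the structure stays the same.

The measured steps that bear on this are a step that the two limits leave unreadable from compound 1 to compound 2 and a step that the two limits leave unreadable from compound 1 to compound 3 and a step that the two limits leave unreadable from compound 2 to compound 3 and none of them has a readable size. All three change the group on a nitrogen, so none tests a change on this aromatic carbon.

With compound 2 at > 50000 nM as a limit, no step beyond the usual scatter is expected in this assay in either direction. The expected change is a number no higher from compound 2 to compound 4 (the limit leaves the size open) and this is only an estimate. For compound 4 the estimated value is 50000 nM with an expected range from 25000 nM to 100000 nM and a report of only a limit is likely.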

Compound 4, half-maximal cytotoxic concentration: > 50000 nM
Compound 4: no number, only a limit; the forecaster's own chance of this, stated with the estimate: 85%; the middle value sits exactly at the limit.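

No size can be read for the change from compound 2 to compound 4, the added methyl on an aromatic carbon, since every value so far is the same limit and not a number: the limit of > 50000 nM in this assay, at which 4 of the 4 values shown sit.

The compounds shown leave open at what concentration any of them harms these cells, and so whether this methyl changes that concentration at all.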